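Oxime ether geometry in the shared core series

The source may report more compounds than this note shows. Statements on the series, on what has been measured and on what is new or still open speak of the compounds shown alone.

Measured so far:
compound 1 `O/N=C(/CCN1CCN(c2ccccn2)CC1)c1ccccc1Cl` — 25 nM
compound 2 `CO/N=C(\CCN1CCN(c2ccccn2)CC1)c1ccccc1Cl` — 42.3 nM

In a functional assay on HEK293 cells with D(4) dopamine receptor (Homo sapiens) as the target, read by FLIPR (on this read-out lower numbers stand for an effect already at smaller amounts and higher numbers for an effect only at larger amounts of compound), compound 1 gives 25 nM and compound 2 gives 42.3 nM. Compound 2 holds the higher of the two numbers, and the gap to compound 1 lies within the scatter, so no order is claimed between them.

Compound 3 `CO/N=C(/CCN1CCN(c2ccccn2)CC1)c1ccccc1Cl` is not yet measured. The change from compound 2 to compound 3 is the two compounds have the same atoms and bonds and differ only in configuration as drawn: 1 of 1 stereo elements differ; a double bond is drawn E in compound 2 and Z in compound 3. Among the measured compounds shown here, no measured pair in this set shows what a double-bond geometry change does here, so the direction of the step is open. A modest shift toward higher numbers is expected for compound 3, at 70 nM with a range of 20 nM to 300 nM. The expected step is a 1.7-fold higher number from compound 2 to compound 3 (0.22 log units; within the scatter).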

Compound 3, half-maximal effective concentration: 57.2 nM
The estimate for compound 3 lay 1.2-fold (0.09 log units) above the measured number, within the range that was stated.
By their numbers in this assay, from the lowest: compounds 1, 2 and 3 (each within the scatter of the next, the first and the last beyond it).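

In this assay the change of the double bond from E to Z gives a 1.4-fold higher number from compound 2 to compound 3 (0.13 log units; within the scatter), so no order is claimed between the two geometries with a methyl group on the oxygen. This pair isolates that single stereo element: the fact that compounds 2 and 3 differ only in the configuration as drawn. Methyl in place of hydrogen on the oxygen gives a 2.3-fold higher number from compound 1 to compound 3 (0.36 log units; beyond the scatter), the first modest step in the series beyond the scatter.

On these data alone, what an ethyl or benzyl group on that oxygen would do remains open. So does whether the two geometries would stay this close with such a group.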